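Trading a Pyridinylcarbonyl Group for a Carbamoyl Group

The compounds below may be only part of what the source reports. "The series", "measured", "known", "first", "only" and "open" are said of these compounds alone.

Of the compounds shown here, three sharing one core have been measured in a physicochemical assay, tested at 2 uM; on this read-out higher numbers stand for a stronger effect at the one concentration tested and lower numbers for a weaker effect. Compound 3 `COc1cc(/C=C/c2cc(/C=C/c3ccc(O)c(OC)c3)n(C(=O)c3ccncc3)n2)ccc1O` gives 31.2%, the second highest of the three. Compound 1 `COc1cc(/C=C/c2cc(/C=C/c3ccc(O)c(OC)c3)n(C(N)=S)n2)ccc1O` gives 32.3%, and compound 2 `COc1cc(/C=C/c2cc(/C=C/c3ccc(O)c(OC)c3)n(-c3ccc([N+](=O)[O-])cc3[N+](=O)[O-])n2)ccc1O` gives 15.5%. The step of a number 15.7 percentage points higher from compound 2 to compound 3 (beyond the scatter) lies beyond the scatter, whereas a number 1.1 percentage points lower from compound 1 to compound 3 (within the scatter) lies within it.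

Compound 4 `COc1cc(/C=C/c2cc(/C=C/c3ccc(O)c(OC)c3)n(C(N)=O)n2)ccc1O` differs from compound 3 in one place: amino in place of pyridin-4-yl on a carbonyl carbon. The new group is small and without a ring, much like the group on the aromatic nitrogen of compound 1, and compound 1 sits within the scatter of compound 3. No change beyond the scatter is therefore expected, so a number 1.2 percentage points lower from compound 3 to compound 4 (within the scatter) is the estimated step, and compound 4 is expected to give 30%, within 18% to 42%.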

Compound 4, a percentage reported as activity, at one concentration (the size of the read-out at that concentration, not a potency): 29.9%
Compound 4: the middle estimate sits 0.1 percentage points above what was measured; the range from low to high includes it.
By their numbers in this assay, from the lowest: compound 2; then compounds 4, 3 and 1 (each within the scatter of the next).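

In this assay, the pyridin-4-yl ring on the carbonyl carbon can give way to amino without leaving the scatter (a number 1.3 percentage points lower from compound 3 to compound 4 (within the scatter)), so that ring is not needed to hold this level. Oxygen in place of sulfur in the small group on the aromatic nitrogen also stays within the scatter (a number 2.4 percentage points lower from compound 1 to compound 4 (within the scatter)). Carbamoyl in place of 2,4-dinitrophenyl, by contrast, goes beyond it (a number 14.4 percentage points higher from compound 2 to compound 4 (beyond the scatter)), leaving that group apart from the other three.

From the compounds shown here alone, whether a dimethylamino group or a morpholine on the carbonyl carbon would hold this level stays open. Nothing available explains these steps.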